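Trading 3,5-Dimethylphenyl for Phenethyl on a Sulfur

The source may hold more compounds than are shown below. What is called first, only, known or untested is meant among the compounds shown, and "the series" means these compounds.

In a functional assay on A-375 cells (Homo sapiens) for inhibition, read by CCK-8 assay, with a stated time of 72 h, tested at 2 uM (a higher number here means more inhibition of growth at the concentration tested, a lower number less inhibition of growth), compound 1 (`Cc1cc(C)cc(SCc2ccc(/C=C/C(=O)Nc3ccccc3N)cc2)c1`) gives 8.78% and compound 2 (`CC(C)(C)c1ccc(SCc2ccc(C(=O)Nc3ccccc3N)cc2)cc1`) gives 2.13% so the two lie within the usual scatter of each other and neither can be ranked. Both numbers are low on this scale. Compound 3 (`Nc1ccccc1NC(=O)/C=C/c1ccc(CSCCc2ccccc2)cc1`) keeps the core of compound 1 but carries phenethyl in place of 3,5-dimethylphenyl on a sulfur so the two compounds hold the same atoms joined differently. Going by the values given here, no measured pair shows what this swap does, which leaves compound 1 at 8.78% as the only starting point for an expectation. An estimated change of a number 1.2 percentage points higher from compound 1 to compound 3 (within the scatter) is expected in this assay and that would be no step beyond the scatter. For compound 3 the expected growth inhibition is 10% with an estimated range from 0% to 26% at the tested concentration.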

Compound 3, percent growth inhibition at one concentration: 41.9%
The estimate for compound 3 lay 31.9 percentage points below the measured number, and the stated range ends below it.
By their numbers in this assay, from the lowest: compounds 2 and 1 (each within the scatter of the next); then compound 3.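

At this place on the sulfur, the choice of group matters a great deal: in this assay, phenethyl in place of 3,5-dimethylphenyl gives a number 33.1 percentage points higher from compound 1 to compound 3 (beyond the scatter), although the two groups hold the same atoms. The core of compound 1 can therefore move from a low reading to a clearly higher one through this single change, something the first two compounds could not show, as they differ in more than one place. Nothing measured here explains the size of this step.

As far as these compounds go, whether a shorter benzyl group or a longer phenylpropyl chain on the sulfur would raise or lower the number remains open. From the compounds shown here alone, it is also open whether phenethyl would give a similar step on the core of compound 2.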